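The compounds below may be only part of what the source reports. "The series", "measured", "known", "first", "only" and "open" are said of these compounds alone.

Measured compounds in this series:
compound 1 `C#CCSc1cnc2ccccc2c1[Se]CC#CCCl` gives 0.8 ug/mL
compound 2 `OCC#CCSc1cnc2ccccc2c1SCC#CCCl` gives 5.1 ug/mL
compound 3 `CSc1cnc2ccccc2c1[Se]CC#CCCl` gives 0.4 ug/mL

In a functional assay on P388 cells (Mus musculus) for antiproliferative activity, with a stated time of 72 h (a lower number here means a stronger inhibitor, a higher number a weaker inhibitor), compound 3 holds the lowest of the three numbers. Among the measured compounds shown here, its nearest neighbour is compound 1; the only one-place step in the set, a 2.0-fold lower number from compound 1 to compound 3 (0.30 log units; within the scatter), does not separate the two, so neither can be ranked over the other. Compound 2 stands furthest away, and the gap between compound 2 and compound 3 lies beyond the scatter; compound 2 differs from compound 3 in more than one place, so only the two values themselves speak.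

Compound 4 `OCC#CCSc1cnc2ccccc2c1[Se]CC#CCCl` is not yet measured. Its difference from compound 3: 3-hydroxyprop-1-yn-1-yl in place of hydrogen on a saturated chain carbon bound to a sulfur

The step bearing on it is the reverse of the ethynyl removal, which in this assay moved the number only within the scatter. The larger chain entering here is also found in compound 2, whose number in this assay is the highest of the set, though compound 2 also differs elsewhere. Taken together, a step upward of modest size is expected for compound 4, a 3.8-fold higher number from compound 3 to compound 4 (0.57 log units; beyond the scatter), possibly no larger than the scatter. Compound 4 is therefore estimated at 1.5 ug/mL, with a range from 0.5 ug/mL to 4.5 ug/mL.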

Compound 4, concentration for 50% inhibition: 2 ug/mL
Beside the measured number, compound 4's estimate is 1.3-fold (0.12 log units) below it; low and high end bracket the measured number.
By their numbers in this assay, from the lowest: compounds 3 and 1 (each within the scatter of the next); then compound 4; then compound 2.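

In this assay, the ethynyl group on the saturated chain carbon bound to a sulfur had not separated compound 1 from compound 3, whereas the 3-hydroxyprop-1-yn-1-yl group at that place gives a step beyond the scatter (a 5.0-fold higher number from compound 3 to compound 4 (0.70 log units; beyond the scatter)). The hydroxymethyl group on the triple-bonded carbon gives a step of similar modest size (a 2.5-fold higher number from compound 1 to compound 4 (0.40 log units; beyond the scatter)), so this position does respond to change, and the rise appears only once that hydroxymethyl end is present among the three selenium compounds. The exchange of the sulfur-linked group on the aromatic carbon for its selenium-linked counterpart can also now be read in one pair, and it goes with a lower number (a 2.6-fold lower number from compound 2 to compound 4 (0.41 log units; beyond the scatter)), while nothing on hand accounts for any of these steps.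

Going by these compounds, whether an amine, a methoxy group or a longer chain at the end of the alkyne would follow the hydroxymethyl group remains open. The selenium-for-sulfur step rests on this single pair carrying the 4-hydroxybut-2-yn-1-yl chain, so its size with a methyl group at the same place is also unknown.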